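The compounds below may be only part of what the source reports. "The series", "measured", "known", "first", "only" and "open" are said of these compounds alone.

Compound 1 `Cn1c(-c2ccccc2)nnc1[S+](C)[O-]` and compound 2 `Cn1c(-c2ccccc2)nnc1S(C)(=O)=O` share one core and differ in a single group. In a functional assay on the whole organism for antagonist activity, with Mus musculus as the target (on this read-out higher numbers stand for an effect only at larger amounts of compound and lower numbers for an effect already at smaller amounts), compound 1 gives 18.6 mg/kg. In this assay compound 2 gives 12.8 mg/kg. The change between them is a group of 4 heavy atoms (1 carbon, 2 oxygen, 1 sulfur; no ring) in place of a group of 3 heavy atoms (1 carbon, 1 oxygen, 1 sulfur; no ring), on an aromatic carbon and it made a step of a 1.5-fold lower number from compound 1 to compound 2 (0.16 log units; within the scatter).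

Compound 3 `Cn1nc([S+](C)[O-])nc1-c1ccccc1` is built from the same atoms as compound 1, joined differently; the difference between the two cores is not broken down here. In this assay compound 3 gives > 200 mg/kg, which is a limit of the assay and not a number (the limit of > 200 mg/kg in this assay, at which 1 of the 3 values shown sits).

Compound 4 `Cn1nc(S(C)(=O)=O)nc1-c1ccccc1` is not yet measured. It differs from compound 3 by a group of 4 heavy atoms (1 carbon, 2 oxygen, 1 sulfur; no ring) in place of a group of 3 heavy atoms (1 carbon, 1 oxygen, 1 sulfur; no ring), on an aromatic carbon. This is the same kind of change as that from compound 1 to compound 2, though the place is not identical: in compound 3 the group sits two ring bonds from the ring atom that bears a methyl group, whereas in compound 1 it sits next to that ring atom.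

For compound 4 a step of a number no higher from compound 3 to compound 4 (the limit leaves the size open) in this assay is expected, resting on a 1.5-fold lower number from compound 1 to compound 2 (0.16 log units; within the scatter). Compound 4 is therefore estimated at 200 mg/kg in this assay, most likely between 100 mg/kg and 400 mg/kg, and it may again be reported only as a limit.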

Compound 4, dose for half-maximal effect: > 200 mg/kg
Compound 4 gave a limit, no number (the forecaster's own chance of this, stated with the estimate: 70%); the middle value lies on the limit itself.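

In this assay, for the compounds shown here, compound 3 and compound 4 both give a limit of the assay and not a number, so no step between them can be read: the limit of > 200 mg/kg in this assay, at which 2 of the 4 values shown sit. The compounds shown leave open how far beyond this limit each of them lies, and whether methylsulfonyl at this place changes the dose at all.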